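The source may hold more compounds than are shown below. What is called first, only, known or untested is meant among the compounds shown, and "the series" means these compounds.

Compound 1 `CCCc1ncc2c(C)nnc(O)n12`, compound 2 `CCCc1nc(C)c2cnnc(SC)n12` and compound 3 `CCCc1nc(C)c2c(C)nnc(SC)n12` share one core, and the still unmeasured compound 4 `CCCc1ncc2c(C)nnc(SC)n12` belongs to the same set. In a functional assay for inhibition, with Homo sapiens as the target (on this read-out lower numbers stand for stronger inhibition and higher numbers for weaker inhibition), compound 1 gives > 48000 nM, which is a limit of the assay and not a number. Compound 2 gives > 48000 nM in this assay, again only a limit. Compound 3 likewise reaches only the limit > 48000 nM in this assay, so its standing is known as a limit alone, in keeping with the limit of > 48000 nM in this assay, at which 3 of the 3 values shown sit. The step that the two limits leave unreadable from compound 2 to compound 3 cannot be read between two limits. Compound 4 differs from compound 3 by hydrogen in place of methyl on an aromatic carbon. The measured step bears on this change but gives no size for it. Compound 4 is therefore expected to show a step that the limit leaves unreadable from compound 3 to compound 4, with the limit again the most likely outcome. The estimate for compound 4 is 80000 nM, between 30000 nM and 250000 nM.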

Compound 4, half-maximal inhibitory concentration: > 48000 nM
Compound 4 was reported as a limit; the forecaster's own chance of this, stated with the estimate: 85%; the middle value lies beyond the limit too.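

Compound 4 gives only a limit of the assay in this assay, so no new step can be read from compound 1 or compound 3 to compound 4: the limit of > 48000 nM in this assay, at which 4 of the 4 values shown sit.

The compounds shown leave open whether any change here alters inhibition, and by how much.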